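Replacing the Ester Side Chain of Compound 1 with Cyclopentyl

The compounds below may be only part of what the source reports. "The series", "measured", "known", "first", "only" and "open" are said of these compounds alone.

In a functional assay on K562 cells (Homo sapiens) for inhibition, read by trypan blue exclusion, with a stated time of 72 h (a higher number here means a weaker inhibitor, a lower number a stronger inhibitor), compound 1 `COC(=O)Cn1c(=O)c(S(=O)(=O)c2ccc(F)cc2F)cc2cnc(Nc3ccc4[nH]ccc4c3)nc21` gives 5000 nM. Compound 2 `CN1CCN(c2ccc(Nc3ncc4cc(S(=O)(=O)c5ccc(F)cc5F)c(=O)n(C)c4n3)cc2)CC1` gives 5000 nM, which leaves compound 1 level with it. Compound 3 `O=c1c(S(=O)(=O)c2ccc(F)cc2F)cc2cnc(Nc3ccc4[nH]ccc4c3)nc2n1C1CCCC1` keeps the core of compound 1 but carries cyclopentyl in place of (methoxycarbonyl)methyl on an aromatic nitrogen. Among the measured compounds shown here, no measured pair isolates this change, so its size remains a judgement. Somewhat stronger inhibition in this assay is expected, with an estimated 5.0-fold lower number from compound 1 to compound 3 (0.70 log units; beyond the scatter). The expected value for compound 3 is 1000 nM, within an estimated range of 150 nM to 5000 nM.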

Compound 3, half-maximal inhibitory concentration: 5000 nM
Compound 3: the middle estimate sits 5.0-fold (0.70 log units) below what was measured, and the stated range covers the measured number.
By their numbers in this assay, from the lowest: compounds 1, 2 and 3 (each within the scatter of the next).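

In this assay, cyclopentyl in place of (methoxycarbonyl)methyl on the aromatic nitrogen gives no change at the digits printed from compound 1 to compound 3 (within the scatter). The number at this position therefore stays put when the side chain loses its hydrogen-bond acceptors and its double bond and gains a carbon-only ring of the same heavy-atom count. No available evidence accounts for this result. On these data alone, whether an amine, a carboxylic acid or a longer chain on this nitrogen would move the number remains open, and so does whether any group here would do so on the core of compound 1.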